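This account rests on a few compounds, and the source may have more. Where it says the series, first, only, none or still open, it means among the compounds named here.

In a physicochemical assay, with a stated time of 6 min (on this read-out lower numbers stand for stronger inhibition and higher numbers for weaker inhibition), compound 1 `O=C(Nc1ccc(I)cc1)Nc1nc(-c2cc3ccccc3o2)cs1` gives 62000 nM. The result for compound 2 `O=C(Nc1ccc(Br)cc1)Nc1nc(-c2cc3ccccc3o2)cs1` is a limit of the assay and not a number: > 200000 nM. Among the measured compounds shown here, compound 3 `O=C(Nc1nc(-c2cc3ccccc3o2)cs1)Nc1ccccc1F` gives 2630 nM, the lowest of the two true numbers so far.

Compound 4 `COc1cccc(NC(=O)Nc2nc(-c3cc4ccccc4o3)cs2)c1` has not yet been measured. It carries 3-methoxyphenyl in place of 2-fluorophenyl on an amide-type nitrogen.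

Earlier changes of the group at this place bear directly on that swap. The data show a 24-fold lower number from compound 1 to compound 3 (1.37 log units; beyond the scatter) and an at least 76-fold lower number from compound 2 to compound 3 (1.88 log units; beyond the scatter), both large, and bromo in place of iodo alone gives an at least 3.2-fold higher number from compound 1 to compound 2 (0.50 log units; beyond the scatter). Numbers here can therefore move a long way, and no measured compound yet carries 3-methoxyphenyl. Both groups that differ from 2-fluorophenyl gave higher numbers, so a moderate rise is expected, though with wide uncertainty. The expected step is a 3.4-fold higher number from compound 3 to compound 4 (0.53 log units; beyond the scatter). For compound 4 the estimated value is 9000 nM, with an expected range from 1500 nM to 60000 nM.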

Compound 4, half-maximal inhibitory concentration: 200 nM
Beside the measured number, compound 4's estimate is 45-fold (1.65 log units) above it, outside the stated range (below it).
By their numbers in this assay, from the lowest: compound 4; then compound 3; then compound 1. At a limit, above all of these: compound 2.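

In this assay, 3-methoxyphenyl in place of 2-fluorophenyl on the amide-type nitrogen gives a 13-fold lower number from compound 3 to compound 4 (1.12 log units; beyond the scatter) and shows that 2-fluorophenyl, the lowest so far, does not mark the floor at this place. Among the compounds shown here, the same group gives a 310-fold lower number from compound 1 to compound 4 (2.49 log units; beyond the scatter) against 4-iodophenyl and an at least 1000-fold lower number from compound 2 to compound 4 (3.00 log units; beyond the scatter) against 4-bromophenyl in a series where only this group and its ring substituent vary, so this one place alone spans a very wide range. Compound 2 stands at a limit of the assay and not at a number, which makes its step a bound only: the limit of > 200000 nM in this assay, at which 1 of the 4 values shown sits.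

With only these four compounds, the part played by the methoxy group cannot be separated from the loss of fluorine. On these data alone, whether an amine, a carboxylic acid or a longer chain such as ethoxy on the phenyl ring would lower the number further stays open.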